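Paired amide series: methoxy-to-methyl swap in a second core

A few compounds are considered here, and "the series" means these few. Any claim that something is new, unique, unknown or untested is made for them only; others in the source may bear on it.

Compound 1 `COc1cccc(C(=O)NN(C(=O)c2ccccc2Cl)C(C)(C)C)c1` gives 52.5 nM in an assay on cells for agonist activity at ecdysone receptor (Bombyx mori), read by a luciferase reporter, with a stated time of 24 h; on this read-out lower numbers stand for an effect already at smaller amounts and higher numbers for an effect only at larger amounts of compound. Compound 2 `Cc1ccc(C(=O)NN(C(=O)c2ccccc2Cl)C(C)(C)C)cc1`, in this assay, gives 18.6 nM. The change between them is 4-methylphenyl in place of 3-methoxyphenyl on a carbonyl carbon, and it made a step of a 2.8-fold lower number from compound 1 to compound 2 (0.45 log units; beyond the scatter). Compound 3 `COc1cccc(C(=O)NN(C(=O)c2cc(C)cc(C)c2)C(C)(C)C)c1` shares the other aryl amide of compound 1 but carries a second core that differs by 3,5-dimethylphenyl in place of 2-chlorophenyl on a carbonyl carbon; in this assay compound 3 gives 66.1 nM, a step of a 1.3-fold higher number from compound 1 to compound 3 (0.10 log units; within the scatter).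

Compound 4 `Cc1ccc(C(=O)NN(C(=O)c2cc(C)cc(C)c2)C(C)(C)C)cc1` has not been measured. It differs from compound 3 by 4-methylphenyl in place of 3-methoxyphenyl on a carbonyl carbon, which is the same change as that from compound 1 to compound 2, at a place that reads the same in both cases. The change occurs twice among the four compounds, once measured. The only basis for an expectation is that single measured step, and the difference between the two cores, (3,5-dimethylphenyl in place of 2-chlorophenyl on a carbonyl carbon), lay within the scatter, so nothing in the data suggests the second core behaves differently here.

On that basis the step from compound 3 to compound 4 in this assay is expected to be about a 2.8-fold lower number from compound 3 to compound 4 (0.44 log units; beyond the scatter), close to the earlier one, because compound 1 to compound 2 gave a 2.8-fold lower number from compound 1 to compound 2 (0.45 log units; beyond the scatter). Compound 4 is therefore estimated at 24 nM, with a range from 10 nM to 55 nM.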

Compound 4, half-maximal effective concentration: 12 nM
For compound 4 the middle estimate is 2.0-fold (0.30 log units) above the measured one; low and high end bracket the measured number.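

In this assay, 4-methylphenyl in place of 3-methoxyphenyl on a carbonyl carbon gives a 5.5-fold lower number from compound 3 to compound 4 (0.74 log units; beyond the scatter), in the same direction as the step on the core of compound 1, and the two steps do not differ beyond their scatter: the same change on two cores in this assay, a 2.8-fold lower number (0.45 log units; beyond the scatter) from compound 1 to compound 2 and a 5.5-fold lower number (0.74 log units; beyond the scatter) from compound 3 to compound 4, 2.0-fold (0.29 log units) apart, within the scatter of two such steps Read the other way, 3,5-dimethylphenyl in place of 2-chlorophenyl on a carbonyl carbon gives a 1.6-fold lower number from compound 2 to compound 4 (0.19 log units; within the scatter), so this change stays small with either aryl amide in place: the same change on two cores in this assay, a 1.3-fold higher number (0.10 log units; within the scatter) from compound 1 to compound 3 and a 1.6-fold lower number (0.19 log units; within the scatter) from compound 2 to compound 4, 2.0-fold (0.29 log units) apart, within the scatter of two such steps The change therefore carries over between these two cores in direction and, within the scatter, in size, but this rests on a single pair of steps in one assay and shows nothing about other cores or other read-outs.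

Open, as far as these compounds go, is whether the step holds when the methyl of 4-methylphenyl gives way to a longer chain, an amine or a carboxylic acid. Also open, from the compounds shown here alone, is how either group compares with an unsubstituted phenyl, so the step cannot yet be split into a part from losing the methoxy and a part from gaining the methyl.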